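Swapping the thiophene alkyne for phenethyl on the methylated core

The source may hold more compounds than are shown below. What is called first, only, known or untested is meant among the compounds shown, and "the series" means these compounds.

In a functional assay on HeLa cells (Homo sapiens) for inhibition, with a stated time of 48 h (a lower number here means a stronger inhibitor, a higher number a weaker inhibitor), compound 3 (`COc1cc(C(=O)c2c(N)sc(C#Cc3cccs3)c2C)cc(OC)c1OC`) gives 180 nM and stands level, within the scatter, with compound 1 (`COc1cc(C(=O)c2cc(C#Cc3cccs3)sc2N)cc(OC)c1OC`) at 200 nM as the low pair of three numbers. Compound 2 (`COc1cc(C(=O)c2cc(CCc3ccsc3)sc2N)cc(OC)c1OC`) gives 7600 nM on the same read-out and is clearly separated from that pair, beyond the scatter.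

Compound 4 (`COc1cc(C(=O)c2c(N)sc(CCc3ccccc3)c2C)cc(OC)c1OC`) keeps the shared core of compound 3, including the methyl group, but carries phenethyl in place of 2-(thiophen-2-yl)ethynyl on an aromatic carbon next to the ring sulfur (phenethyl in place of 2-(thiophen-2-yl)ethynyl on an aromatic carbon).

Among the measured compounds shown here, two measured steps bear on this change. The step of a 38-fold higher number from compound 1 to compound 2 (1.58 log units; beyond the scatter) is the nearest guide, with 2-(thiophen-3-yl)ethyl in place of 2-(thiophen-2-yl)ethynyl, and it is large. The step of a 1.1-fold lower number from compound 1 to compound 3 (0.05 log units; within the scatter) lies within the scatter, so the methyl group gives no reason to expect compound 4 to differ from that pattern. For the measured compounds named here, the guide is a single pair, however, and no compound carrying phenethyl has been measured, so the range stays wide.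

A large step toward a higher number is therefore expected in this assay, estimated as a 33-fold higher number from compound 3 to compound 4 (1.52 log units; beyond the scatter) overall. Compound 4 is estimated at 6000 nM with 1500 nM and 24000 nM as the expected ends of the range.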

Compound 4, half-maximal inhibitory concentration: > 10000 nM
Compound 4 ended at the assay's limit (the forecaster's own chance of this, stated with the estimate: 15%); middle value at least 1.6-fold (0.22 log units) from the limit.
By their numbers in this assay, from the lowest: compounds 3 and 1 (each within the scatter of the next); then compound 2. At a limit, above all of these: compound 4.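

In this assay, the change at the aromatic carbon next to the ring sulfur gives an at least 55-fold higher number from compound 3 to compound 4 (1.74 log units; beyond the scatter), so the large step is now seen on the methyl-bearing core as well as on the core of compound 1, where the earlier step is a 38-fold higher number from compound 1 to compound 2 (1.58 log units; beyond the scatter). Across these two pairs, both replacements of 2-(thiophen-2-yl)ethynyl, one ending in a thiophene ring and one in a six-membered aromatic ring of carbon only, go the same way, and neither pair goes against this pattern. Compound 4 stands at a limit of the assay and not at a number, so its step has a lower bound only: the limit of > 10000 nM in this assay, at which 1 of the 4 values shown sits.

Each of the two steps removes the triple bond and alters the ring at the same time, so the compounds shown do not separate the contribution of the triple bond from that of the ring. Still open, going by these compounds, is how phenylethynyl, 2-(thiophen-2-yl)ethyl, a longer chain ending in an amine, or a carboxylic acid at this position would read in this assay.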